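Replacing the 1-benzothiophen-5-yl group of compound 1

A few compounds are considered here, and "the series" means these few. Any claim that something is new, unique, unknown or untested is made for them only; others in the source may bear on it.

In a functional assay on K562 cells (Homo sapiens) for inhibition, read by trypan blue exclusion, with a stated time of 72 h (on this read-out higher numbers stand for weaker inhibition and lower numbers for stronger inhibition), compound 1 (`Cn1c(=O)c(S(=O)(=O)c2ccc(F)cc2F)cc2cnc(Nc3ccc4sccc4c3)nc21`) gives 500 nM as the lower of the two numbers available. Compound 2 (`Cn1c(=O)c(S(=O)(=O)c2ccc(F)cc2)cc2cnc(Nc3ccc4[nH]ncc4c3)nc21`) gives 10000 nM and so stands well beyond the scatter on the weaker side. Within the data shown here, the series offers no measured step confined to a single place, so any forecast here is loosely anchored.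

Compound 3 (`Cn1c(=O)c(S(=O)(=O)c2ccc(F)cc2F)cc2cnc(Nc3ccc4cccc(O)c4n3)nc21`) carries 8-hydroxyquinolin-2-yl in place of 1-benzothiophen-5-yl on a nitrogen on an aromatic ring. Compound 1 at 500 nM holds the lower of the two measured numbers, so a move towards weaker inhibition is the more likely direction. The expected size of that move in this assay is moderate (a 4.0-fold higher number from compound 1 to compound 3 (0.60 log units; beyond the scatter)) and remains uncertain. For compound 3 the estimated value is 2000 nM with an expected range from 400 nM to 10000 nM in this working forecast.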

Compound 3, half-maximal inhibitory concentration: 5000 nM
Beside the measured number, compound 3's estimate is 2.5-fold (0.40 log units) below it; measured number inside the range.
By their numbers in this assay, from the lowest: compound 1; then compounds 3 and 2 (each within the scatter of the next).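

In this assay, among these compounds, the exchange of 1-benzothiophen-5-yl for 8-hydroxyquinolin-2-yl on a nitrogen on an aromatic ring gives the first step confined to one place, a 10-fold higher number from compound 1 to compound 3 (1.00 log units; beyond the scatter), so this position does respond to the group it carries. The step combines several changes: a six-membered aromatic ring with 1 hetero atom replaces a five-membered one, and the group goes from 0 to 1 hydrogen-bond donor and from 1 to 2 hydrogen-bond acceptors, with no way to separate their shares. Nothing at hand bears on the cause of this step.

The compounds shown leave open whether the hydroxy group or the change of ring system carries the step. A quinolin-2-yl group without the hydroxy group, or with a methoxy group in its stead, would separate the two.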